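Removing the phenol on a benzothiazole-bearing core

The compounds below may be only part of what the source reports. "The series", "measured", "known", "first", "only" and "open" are said of these compounds alone.

Four compounds share a thioether-linked piperazine scaffold and are compared in a functional assay on MCF7 cells (Homo sapiens) for inhibition, read by MTT assay, with a stated time of 72 h; a higher number here means a weaker inhibitor, a lower number a stronger inhibitor. Compound 1 `Oc1ccc(-c2nnc(SCCCN3CCN(c4nc5ccccc5o4)CC3)o2)cc1` gives 260000 nM in this assay. Compound 2 `c1ccc(-c2nnc(SCCCN3CCN(c4nc5ccccc5o4)CC3)o2)cc1` differs from compound 1 by hydrogen in place of hydroxy on an aromatic carbon; in this assay compound 2 gives 117000 nM, which is a 2.2-fold lower number from compound 1 to compound 2 (0.35 log units; beyond the scatter). Compound 3 `Oc1ccc(-c2nnc(SCCCN3CCN(c4nc5ccccc5s4)CC3)o2)cc1` differs from compound 1 by 1,3-benzothiazol-2-yl in place of 1,3-benzoxazol-2-yl on an amine nitrogen in a ring; in this assay compound 3 gives 81900 nM, which is a 3.2-fold lower number from compound 1 to compound 3 (0.50 log units; beyond the scatter). Among the three, compound 3 gives the lowest number; the gap to compound 2 lies within the scatter, so no order between these two can be claimed.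

Compound 4 `c1ccc(-c2nnc(SCCCN3CCN(c4nc5ccccc5s4)CC3)o2)cc1` is not yet measured. It differs from compound 3 by hydrogen in place of hydroxy on an aromatic carbon, the same change that separates compound 1 from compound 2, now made on the core of compound 3. For compound 4 a step of a 2.0-fold lower number from compound 3 to compound 4 (0.31 log units; beyond the scatter) is expected in this assay, resting on the step seen from compound 1 to compound 2, a 2.2-fold lower number from compound 1 to compound 2 (0.35 log units; beyond the scatter), and the value of compound 3, 81900 nM. Compound 4 is therefore estimated at 40000 nM, with a plausible range from 15000 nM to 110000 nM.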

Compound 4, half-maximal inhibitory concentration: 76900 nM
Compound 4: middle estimate off by 1.9-fold (0.28 log units), on the low side; measured number inside the range.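

In this assay, the change from 4-hydroxyphenyl to phenyl on the core of compound 3 gives a 1.1-fold lower number from compound 3 to compound 4 (0.03 log units; within the scatter), and set beside the earlier step on the core of compound 1, it does not differ measurably between the two cores: the same change on two cores in this assay, a 2.2-fold lower number (0.35 log units; beyond the scatter) from compound 1 to compound 2 and a 1.1-fold lower number (0.03 log units; within the scatter) from compound 3 to compound 4, 2.1-fold (0.32 log units) apart, within the scatter of two such steps. The exchange of 1,3-benzoxazol-2-yl for 1,3-benzothiazol-2-yl reads the same way, with a 1.5-fold lower number from compound 2 to compound 4 (0.18 log units; within the scatter) set beside the earlier step on the 4-hydroxyphenyl compounds: the same change on two cores in this assay, a 3.2-fold lower number (0.50 log units; beyond the scatter) from compound 1 to compound 3 and a 1.5-fold lower number (0.18 log units; within the scatter) from compound 2 to compound 4, 2.1-fold (0.32 log units) apart, within the scatter of two such steps. Neither change is thus shown to behave differently on the other core, but this does not prove that either carries over unchanged, as one step of each pair lies within the scatter and each comparison rests on only two cores.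

The compounds shown leave open whether a methoxy group or a fluorine atom in place of the hydroxy would change the number in this assay. They also leave open what a shorter or longer chain in the thioether link would do.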